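This account rests on a few compounds, and the source may have more. Where it says the series, first, only, none or still open, it means among the compounds named here.

Working notes on the series. The shared core of compound 1 `COc1cc2cc(Oc3ccc(NC(=O)Nc4ccc(C)cc4)cc3)c(C)nc2cc1OC` carries a urea whose far aryl ring is varied. In a functional assay on SF-539 cells (Homo sapiens) for inhibition, read by sulforhodamine B assay, with a stated time of 48 h, tested at 10 uM (on this read-out lower numbers stand for a stronger effect and higher numbers for a weaker effect at the one concentration tested), compound 1 gives 108%. Compound 2 `COc1cc2cc(Oc3ccc(NC(=O)Nc4cccc(C(F)(F)F)c4)cc3)c(C)nc2cc1OC` gives 11.7%, and compound 3 `COc1cc2cc(Oc3ccc(NC(=O)Nc4ccc(Cl)c(C(F)(F)F)c4)cc3)c(C)nc2cc1OC` gives -36.2%. Compound 3 therefore stands lowest of the three numbers, its nearest neighbour being compound 2 and the furthest compound 1. The steps measured so far are all large: a number 96.3 percentage points lower from compound 1 to compound 2 (beyond the scatter), a number 144.2 percentage points lower from compound 1 to compound 3 (beyond the scatter) and a number 47.9 percentage points lower from compound 2 to compound 3 (beyond the scatter).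

The next compound, compound 4 `COc1cc2cc(Oc3ccc(NC(=O)Nc4ccc(Cl)c(Cl)c4)cc3)c(C)nc2cc1OC`, differs from compound 3 in one place: chloro in place of trifluoromethyl on an aromatic carbon. Among the compounds with values here, no measured step exchanges chloro for trifluoromethyl, so none bears on it directly. What bears on it indirectly is that both aryl groups carrying a trifluoromethyl gave low numbers, and that adding chloro also gave a low number, as a number 47.9 percentage points lower from compound 2 to compound 3 (beyond the scatter) shows. Compound 4 keeps the chloro that enters in that step and keeps two substituents on the ring, so a small step in either direction, or none beyond the scatter, is expected. Compound 4 is estimated at -15%, within -60% to 30%, which would mean a step of a number 21.2 percentage points higher from compound 3 to compound 4 (beyond the scatter).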

Compound 4, a percentage reported as activity, at one concentration (the size of the read-out at that concentration, not a potency): 38.5%
For compound 4 the middle estimate is 53.5 percentage points below the measured one; measured number outside the range, above it.
By their numbers in this assay, from the lowest: compound 3; then compound 2; then compound 4; then compound 1.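

In this assay, within the data shown here, trifluoromethyl and chloro are not interchangeable on this aromatic carbon, ortho to a chloro group: a number 74.7 percentage points higher from compound 3 to compound 4 (beyond the scatter), the first direct exchange of the two groups. A chloro group on the far ring therefore does not secure a low number by itself, since a number 26.8 percentage points higher from compound 2 to compound 4 (beyond the scatter), so that 3,4-dichlorophenyl lies above 3-(trifluoromethyl)phenyl, which carries no chloro, although a number 69.5 percentage points lower from compound 1 to compound 4 (beyond the scatter) keeps it clearly below 4-methylphenyl. Nothing measured on these compounds accounts for the gap between trifluoromethyl and chloro at this place.

As far as these compounds go, with only four aryl groups in hand, it remains open whether the low numbers are specific to trifluoromethyl or would also appear with another group on the same carbon, such as a nitrile or a methoxy group, with the chloro kept in place. From the compounds shown here alone, it is also open how much the chloro contributes on its own, which a far ring bearing only a single chloro, as in 4-chlorophenyl, would help to separate from the effect of the second substituent.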